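The source may hold more compounds than are shown below. What is called first, only, known or untested is meant among the compounds shown, and "the series" means these compounds.

Among the measured compounds shown here, in a functional assay on DU-145 cells (Homo sapiens) for cytotoxicity, read by MTT assay (a lower number here means a stronger inhibitor, a higher number a weaker inhibitor), compound 1 `CC(C)C[C@@H](NC(=S)Nc1ccccc1)c1nc2ccccc2[nH]1` gives 20000 nM, one of only two numbers recorded; the other belongs to compound 2 `CC(C)C[C@H](NC(=S)Nc1ccccc1)c1nc2ccccc2[nH]1`, which gives 28900 nM, and the step of a 1.4-fold higher number from compound 1 to compound 2 (0.16 log units; within the scatter) rests on the fact that compounds 1 and 2 differ only in the configuration as drawn and stays within the scatter. Compound 3 `C[C@@H](NC(=S)Nc1ccccc1)c1nc2ccccc2[nH]1`, not yet measured, differs from compound 1 by hydrogen in place of isopropyl on a saturated chain carbon, two bonds along the chain from an amide-type nitrogen and an aromatic carbon. For the measured compounds named here, the single measured step, that between compound 1 and compound 2, concerns configuration alone and says nothing about shortening the chain, so no measured step bears on the change to compound 3. With no anchor for a direction, the expected step of a 1.5-fold higher number from compound 1 to compound 3 (0.18 log units; within the scatter) in this assay is kept modest and is hedged with a wide range. Compound 3 is therefore estimated at 30000 nM in this assay, with a range from 10000 nM to 100000 nM.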

Compound 3, half-maximal inhibitory concentration: 22100 nM
Estimate against measurement, compound 3: 1.4-fold (0.13 log units) above, and the stated range covers the measured number.
By their numbers in this assay, from the lowest: compounds 1, 3 and 2 (each within the scatter of the next).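

In this assay, putting hydrogen in place of isopropyl on the saturated chain carbon, two bonds along the chain from an amide-type nitrogen and an aromatic carbon, gives a 1.1-fold higher number from compound 1 to compound 3 (0.04 log units; within the scatter). The earlier pair had varied only the configuration at this carbon, whereas this result shows that the group carried there can also be cut back, from isobutyl to methyl, without a step beyond the scatter. Nothing measured here offers an explanation for this result.

Going by these compounds, it remains open whether a longer chain, a phenyl group or an amine at this position would also stay within the scatter of compound 1. Also open, on these data alone, is whether the opposite configuration of compound 3 would stay within the scatter as well.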